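Replacing 3,5-difluorophenyl with 3,5-dimethylphenyl: working notes

The compounds below may be only part of what the source reports. "The series", "measured", "known", "first", "only" and "open" are said of these compounds alone.

In a functional assay on RT-112 cells (Homo sapiens) for antiproliferative activity, read by MTT assay, with a stated time of 72 h (a lower number here means a stronger inhibitor of growth, a higher number a weaker inhibitor of growth), compound 1 `COc1cc(Nc2ncnc3c(NC(=O)Nc4cccc(Oc5ccccc5)c4)cccc23)cc(OC)c1` gives 14000 nM, compound 2 `COc1cc(Nc2ncnc3c(NC(=O)Nc4cc(F)cc(F)c4)cccc23)cc(OC)c1` gives 2630 nM and compound 3 `COc1cc(Nc2ncnc3c(NC(=O)Nc4cc(C(F)(F)F)cc(C(F)(F)F)c4)cccc23)cc(OC)c1` gives 467 nM. Compound 2 therefore stands in the middle of the three, with the gaps to compound 1 and compound 3 both beyond the scatter. Compound 4 `COc1cc(Nc2ncnc3c(NC(=O)Nc4cc(C)cc(C)c4)cccc23)cc(OC)c1` carries 3,5-dimethylphenyl in place of 3,5-difluorophenyl on an amide-type nitrogen. Among the compounds with values here, no measured pair differs in one place only, so the data give no direct measure of this change. No shift beyond the scatter is expected in this assay, in either direction. The estimated step is a 1.1-fold lower number from compound 2 to compound 4 (0.02 log units; within the scatter). For compound 4 the expected value is 2500 nM, with an estimated range of 800 nM to 8000 nM.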

Compound 4, concentration for 50% growth inhibition: 10100 nM
Beside the measured number, compound 4's estimate is 4.0-fold (0.61 log units) below it; measured number outside the range, above it.
By their numbers in this assay, from the lowest: compound 3; then compound 2; then compounds 4 and 1 (each within the scatter of the next).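

In this assay the swap on the amide-type nitrogen can now be read directly: 3,5-dimethylphenyl in place of 3,5-difluorophenyl gives a 3.8-fold higher number from compound 2 to compound 4 (0.58 log units; beyond the scatter), a modest loss of growth inhibition. This position is therefore sensitive to the substituents on the ring, and methyl does not stand in for fluorine here, although the ring itself is unchanged. Nothing available explains this step.

Going by these compounds, whether 3,5-dichlorophenyl or unsubstituted phenyl on the same nitrogen would track compound 2 or compound 4 remains open. Also open, on these data alone, is whether the step holds on a different core.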